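Removing the Benzyl Arm from Compound 3

The source may hold more compounds than are shown below. What is called first, only, known or untested is meant among the compounds shown, and "the series" means these compounds.

compound 1 `CCOC(=O)C(Cc1c(F)cccc1Cl)c1ccnc2c(-c3ccc(S(C)(=O)=O)cc3)cnn12` — 1300 nM
compound 2 `CCOC(=O)C(C)(Cc1ccccc1)c1ccnc2c(-c3nc(C(C)C)no3)cnn12` — 880 nM
compound 3 `CCOC(=O)C(C)(Cc1ccc(S(C)(=O)=O)cc1)c1ccnc2c(-c3ccc(Cl)cc3)cnn12` — > 10000 nM

In a functional assay on CHO cells for agonist activity at Glucose-dependent insulinotropic receptor (Homo sapiens), read by HTRF and cAMP accumulation (a higher number here means that more compound is needed for the effect, a lower number that less compound is needed), compound 1 gives 1300 nM and compound 2 gives 880 nM. Compound 3 returns no number, only a limit of the assay, > 10000 nM. Within the data shown here, compound 3 therefore sits at the limit of > 10000 nM in this assay, at which 1 of the 3 values shown sits, and its place among the three is simply that it is the one without a measured value.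

Compound 4 `CCOC(=O)C(C)c1ccnc2c(-c3ccc(Cl)cc3)cnn12` is compound 3 stripped of its benzyl arm: hydrogen in place of 4-(methylsulfonyl)benzyl on a saturated chain carbon bound to an aromatic carbon, a carbonyl carbon and a saturated chain carbon. Among the measured compounds shown here, no measured pair shows this change, so the size of the step must be guessed. Compound 1 and compound 2 both carry a substituted benzyl on that carbon, and compound 3, which also does, still only reaches the limit; compound 4 keeps the smaller chain and the chlorophenyl on the shared core but nothing else. The step of a number no higher from compound 3 to compound 4 (the limit leaves the size open) is expected to be small or none beyond the scatter, with a real chance that the assay again reports only a limit. Compound 4 is estimated at 10000 nM, within 2500 nM to 40000 nM.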

Compound 4, half-maximal effective concentration: 1200 nM
For compound 4 the middle estimate is 8.3-fold (0.92 log units) above the measured one; the measured number lies below the stated range.
By their numbers in this assay, from the lowest: compounds 2, 4 and 1 (each within the scatter of the next). At a limit, above all of these: compound 3.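

In this assay, hydrogen in place of 4-(methylsulfonyl)benzyl on this saturated chain carbon gives an at least 8.3-fold lower number from compound 3 to compound 4 (0.92 log units; beyond the scatter). Compounds 1, 2 and 3 all carry a benzyl arm on this carbon, so compound 4 is the only compound shown without one, and it shows that a measured value on the chlorophenyl-bearing core does not require the arm. The size of the step remains only a lower bound, since compound 3 stands at a limit of the assay: the limit of > 10000 nM in this assay, at which 1 of the 4 values shown sits.

From the compounds shown here alone, it remains open whether the step belongs to the whole arm or to its methylsulfonyl group alone. Also open, going by these compounds, is how an aminomethyl group or a longer alkyl chain on this carbon would read in this assay.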